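Swapping the ring on the sulfur, starting from a limit

A few compounds are considered here, and "the series" means these few. Any claim that something is new, unique, unknown or untested is made for them only; others in the source may bear on it.

Compound 1 `Cc1ccc2oc(CSc3nnc(N)s3)cc(=O)c2c1` was tested in a functional assay on HeLa cells (Homo sapiens) for cytotoxicity, read by MTT assay, with a stated time of 72 h; a lower number here means a stronger inhibitor, a higher number a weaker inhibitor. In this assay compound 1 gives > 25000 nM, which is a limit of the assay rather than a number. Two close relatives share its core. Compound 2 `O=c1c(CSc2nc3ccccc3o2)coc2ccccc12` gives > 25000 nM in this assay, again a limit. Compound 3 `Nc1nnc(SCc2cc(=O)c3cc(Cl)ccc3o2)s1` gives > 25000 nM in this assay, also a limit. For the measured compounds named here, the only measured step, chloro in place of methyl on an aromatic carbon, is a step that the two limits leave unreadable from compound 1 to compound 3, and the two limits leave its size unreadable. What the measurements show is the limit of > 25000 nM in this assay, at which 3 of the 3 values shown sit.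

Compound 4 `Cc1ccc2oc(CSc3nnc(C)o3)cc(=O)c2c1` differs from compound 1 in one place: 5-methyl-1,3,4-oxadiazol-2-yl in place of 5-amino-1,3,4-thiadiazol-2-yl on a sulfur. Going by the values given here, no measured step touches this change, and no measured step here shows any movement beyond the scatter. Compound 4 is therefore expected to remain at the limit as well, with an estimated step that the limit leaves unreadable from compound 1 to compound 4. The estimate for compound 4 in this assay is 40000 nM, expected within a range from 15000 nM to 120000 nM.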

Compound 4, half-maximal inhibitory concentration: > 25000 nM
Compound 4 gave a limit, no number; the forecaster's own chance of this, stated with the estimate: 80%; the middle value does not contradict the limit.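

For the compounds shown here, compound 1 and compound 4 both give limits rather than numbers, and no step between them can be read. The compounds shown leave open whether any change to the group on the sulfur can shift cytotoxicity at all, as all of them share one result: the limit of > 25000 nM in this assay, at which 4 of the 4 values shown sit.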